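A few compounds are considered here, and "the series" means these few. Any claim that something is new, unique, unknown or untested is made for them only; others in the source may bear on it.

In a functional assay on the whole organism (strain Wistar) for inhibition, with Rattus norvegicus as the target, read by paw edema, with a stated time of 30 min, at a dose of 50 mg/kg by the oral route (on this read-out higher numbers stand for more inhibition at the one dose given (going by the name of the read-out) and lower numbers for less inhibition), compound 1 `Cc1ccc(C2=NN(c3ccc([N+](=O)[O-])cc3)C(c3cn(-c4ccccc4)nc3-c3ccc(Cl)c(Cl)c3)C2)cc1` gives 57.4% and compound 2 `Cc1ccc(C2=NNC(c3cn(-c4ccccc4)nc3-c3ccc(Cl)c(Cl)c3)C2)cc1` gives 38.3%. Going by the values given here, the only step measured between two compounds differing in one place is a number 19.1 percentage points lower from compound 1 to compound 2 (beyond the scatter), hydrogen in place of 4-nitrophenyl on an amine nitrogen in a ring. Compound 3 `Clc1ccc(C2=NN(c3ccccc3)C(c3cn(-c4ccccc4)nc3-c3ccc(Cl)c(Cl)c3)C2)cc1` gives 45.7%, the second highest of the three numbers, within the scatter of compound 2 and beyond it from compound 1. Compound 4 `Cc1ccc(C2=NN(c3ccccc3)C(c3cn(-c4ccccc4)nc3-c3ccc(Cl)c(Cl)c3)C2)cc1` differs from compound 3 by methyl in place of chloro on an aromatic carbon. Among the compounds with values here, no measured step bears on this exchange of chloro for methyl, so in this assay no step beyond the scatter is expected, a number 1.3 percentage points higher from compound 3 to compound 4 (within the scatter). Compound 4 is therefore estimated at 47%, between 35% and 60%.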

Compound 4, a percentage reported as inhibition, in the whole organism at one dose (the size of the read-out at that dose, not a potency): 46.8%
The estimate for compound 4 lay 0.2 percentage points above the measured number; low and high end bracket the measured number.
By their numbers in this assay, from the lowest: compounds 2, 3 and 4 (each within the scatter of the next); then compound 1.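

In this assay, the exchange of 4-chlorophenyl for 4-methylphenyl gives a number 1.1 percentage points higher from compound 3 to compound 4 (within the scatter) and so separates these two groups at this position by no more than the scatter. Phenyl in place of hydrogen on the ring nitrogen gives a number 8.5 percentage points higher from compound 2 to compound 4 (within the scatter) whereas hydrogen in place of nitro on an aromatic carbon gives a number 10.6 percentage points lower from compound 1 to compound 4 (beyond the scatter) and so, of these two single changes, only the loss of nitro moves the number beyond the scatter. No evidence on the cause of these steps is available.

From the compounds shown here alone, whether a methoxy group or an amine at this position would read the same as methyl and chloro remains open.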